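From methyl to chloro on compound 1

The source may report more compounds than this note shows. Statements on the series, on what has been measured and on what is new or still open speak of the compounds shown alone.

Values in a functional assay on MCF7 cells (Homo sapiens) for antiproliferative activity, read by MTT assay, with a stated time of 48 h; a lower number here means a stronger inhibitor, a higher number a weaker inhibitor:
- compound 1 `Cc1ccc2nc(NC(c3cn(-c4ccccc4)nc3-c3cccc([N+](=O)[O-])c3)c3c(O)ccc4ccccc34)sc2c1` gives 38400 nM
- compound 2 `Cc1ccc2nc(NC(c3cn(-c4ccccc4)nc3-c3cccc(Cl)c3)c3c(O)ccc4ccccc34)sc2c1` gives 49700 nM
- compound 3 `O=[N+]([O-])c1ccc(-c2nn(-c3ccccc3)cc2C(Nc2nc3ccccc3s2)c2c(O)ccc3ccccc23)cc1` gives 14700 nM

Compound 1 stands second highest of the three numbers in this assay by a margin within the scatter of compound 2, while compound 3 sits lower, beyond the scatter. The next analogue, compound 4 `O=[N+]([O-])c1cccc(-c2nn(-c3ccccc3)cc2C(Nc2nc3ccc(Cl)cc3s2)c2c(O)ccc3ccccc23)c1`, carries chloro in place of methyl on an aromatic carbon, as 6-methyl-1,3-benzothiazol-2-yl becomes 6-chloro-1,3-benzothiazol-2-yl, and the count reads chloro in place of methyl on an aromatic carbon here. Among the measured compounds shown here, no measured step makes this exchange. For the measured compounds named here, the only single-place step, a 1.3-fold higher number from compound 1 to compound 2 (0.11 log units; within the scatter), puts chloro in place of nitro elsewhere in the molecule. Compound 3 differs from compound 1 in more than one place, so its gap gives no size for this change. No shift beyond the scatter is therefore expected in this assay, and the estimated change is a 1.2-fold lower number from compound 1 to compound 4 (0.07 log units; within the scatter) in this reading. Compound 4 is estimated at 33000 nM, with an expected range from 14000 nM to 70000 nM in this assay.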

Compound 4, half-maximal inhibitory concentration: 19700 nM
For compound 4 the middle estimate is 1.7-fold (0.22 log units) above the measured one; measured number inside the range.
By their numbers in this assay, from the lowest: compounds 3, 4, 1 and 2 (each within the scatter of the next, the first and the last beyond it).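

In this assay, among the compounds shown here, the exchange on the aromatic carbon gives the first direct reading at this position (a 1.9-fold lower number from compound 1 to compound 4 (0.29 log units; within the scatter)), since the earlier single-place step concerned chloro and nitro elsewhere in the molecule. In this one pair, going from 6-methyl-1,3-benzothiazol-2-yl to 6-chloro-1,3-benzothiazol-2-yl does not move the number beyond the scatter, so the two groups cannot be told apart here. Nothing available explains this result, and no cause can be assigned to it.

The compounds shown leave open whether a methoxy group, an amine or a carboxylic acid on this carbon would give a step beyond the scatter. They also leave open whether chloro in place of methyl reads the same when the 3-chlorophenyl group of compound 2 replaces the nitro-bearing ring.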